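This account rests on a few compounds, and the source may have more. Where it says the series, first, only, none or still open, it means among the compounds named here.

Among the measured compounds shown here, in a functional assay on PC-3 cells (Homo sapiens) for antiproliferative activity, read by WST assay, with a stated time of 3 days (on this read-out lower numbers stand for stronger inhibition and higher numbers for weaker inhibition), compound 1 `CCC(C)Oc1c(-c2cc(OC)c(OC)c(OC)c2)oc2ccccc2c1=O` gives 38600 nM, while compound 2 `CCN(CC)CCCCCOc1c(-c2cc(OC)c(OC)c(OC)c2)oc2ccccc2c1=O` gives 6600 nM, the lower of the two numbers measured so far. For the measured compounds named here, only one measured step bears on what comes next: a 5.8-fold lower number from compound 1 to compound 2 (0.77 log units; beyond the scatter). It is modest but beyond the scatter, and it brought the diethylamino group onto the chain. Compound 3 `CCCCCN(CCCCC)CCCOc1c(-c2cc(OC)c(OC)c(OC)c2)oc2ccccc2c1=O` keeps the shared core and alters that chain: dipentylamino in place of 2-(diethylamino)ethyl on a saturated chain carbon, three bonds along the chain from an oxygen on an aromatic ring. Going by the values given here, no measured compound varies the groups on the nitrogen, so the evidence here is indirect and the expectation is tentative. Compound 3 still carries an amine on its chain, and a smaller step than the measured one is expected, towards a lower number. The expected step is a 2.2-fold lower number from compound 2 to compound 3 (0.34 log units; beyond the scatter). For compound 3, the estimated value is 3000 nM, with an expected range of 700 nM to 11000 nM.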

Compound 3, half-maximal inhibitory concentration: 5800 nM
For compound 3 the middle estimate is 1.9-fold (0.29 log units) below the measured one, within the range that was stated.
By their numbers in this assay, from the lowest: compounds 3 and 2 (each within the scatter of the next); then compound 1.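

In this assay, dipentylamino in place of 2-(diethylamino)ethyl gives a 1.1-fold lower number from compound 2 to compound 3 (0.06 log units; within the scatter) and so leaves the number effectively unchanged. This position therefore accepts a clearly larger group, with 11 heavy atoms entering where 7 leave, and this change also moves the nitrogen along the chain, as the alternative reading from 3-(diethylamino)propyl to (dipentylamino)methyl makes plain. No available evidence explains why the number holds steady here. Since the length of the chain and the groups on the nitrogen change together in this step, their separate contributions remain unresolved, and they could even be offsetting each other. Also open, going by these compounds, is how a ring amine such as piperidine, or a carboxylic acid in place of the amine, would read at this position.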